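The compounds below may be only part of what the source reports. "The series", "measured", "known", "first", "only" and "open" are said of these compounds alone.

Compound 2 `Cn1ccc2c(Oc3ccc(NC(=O)c4cn(-c5ccc(Br)cc5)c5ccccc5c4=O)cc3F)ccnc21` gives 1260 nM in a functional assay on HepG2 cells (Homo sapiens) for inhibition, read by MTT assay, with a stated time of 72 h; on this read-out lower numbers stand for stronger inhibition and higher numbers for weaker inhibition; of the two numbers measured, it is the lower one, but only by a 1.6-fold lower number from compound 1 to compound 2 (0.20 log units; within the scatter) against compound 1 `Cn1ccc2c(Oc3ccc(NC(=O)c4cn(-c5ccc(F)cc5)c5ccccc5c4=O)cc3F)ccnc21`, which gives 2010 nM in this assay. Compound 3 `Cn1ccc2c(Oc3ccc(NC(=O)c4cn(-c5ccc(Br)cc5F)c5ccccc5c4=O)cc3F)ccnc21` differs from compound 2 by fluoro in place of hydrogen on an aromatic carbon. Among the measured compounds shown here, the one measured step, a halogen swap on the same ring, stayed within the scatter, and nothing measured bears directly on adding a fluoro at this place. Compound 3 is therefore expected to change by a 1.1-fold lower number from compound 2 to compound 3 (0.02 log units; within the scatter) in this assay, nothing beyond the scatter, with an estimate of 1200 nM and a range from 500 nM to 3000 nM.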

Compound 3, half-maximal inhibitory concentration: 2510 nM
For compound 3 the middle estimate is 2.1-fold (0.32 log units) below the measured one, within the range that was stated.
By their numbers in this assay, from the lowest: compounds 2, 1 and 3 (each within the scatter of the next).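

In this assay, fluoro on an aromatic carbon ortho to a large group, turning 4-bromophenyl into 4-bromo-2-fluorophenyl, gives a 2.0-fold higher number from compound 2 to compound 3 (0.30 log units; within the scatter) and so leaves the number within the scatter. The wider change from 4-fluorophenyl to 4-bromo-2-fluorophenyl gives a 1.2-fold higher number from compound 1 to compound 3 (0.10 log units; within the scatter) and likewise stays within the scatter, so this position accepts fluoro without a step beyond it. No evidence is available that bears on these results.

On these data alone, whether an amine or a methoxy group at this place would give a step beyond the scatter remains open.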